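The compounds below may be only part of what the source reports. "The series", "measured", "known", "first", "only" and "open" are said of these compounds alone.

Measured so far:
compound 1, `Cc1ccc(-n2nc(-c3ccccc3)nc2CNc2ccc(C(=O)NO)cc2)cc1C`: 53%
compound 2, `Cc1cc(C)cc(-n2nc(-c3ccccc3)nc2CNc2ccc(C(=O)NO)cc2)c1`: 49.8%

In an assay on Sf9 cells for inhibition of protein deacetylase HDAC6 (Homo sapiens), read by fluorescence, with a stated time of 40 min, tested at 100 nM (a lower number here means less inhibition, a higher number more inhibition at the concentration tested (going by the name of the read-out)), compound 1 gives 53% and compound 2 gives 49.8%. Among the compounds with values here, compound 2 has the lowest of the two numbers, but its nearest neighbour is compound 1, and the one measured step, a number 3.2 percentage points lower from compound 1 to compound 2 (within the scatter), lies within the scatter, so the two values cannot be ranked. The not yet measured compound 3, `CCc1ccc(-n2nc(-c3ccccc3)nc2CNc2ccc(C(=O)NO)cc2)cc1`, differs from compound 2 by 4-ethylphenyl in place of 3,5-dimethylphenyl on an aromatic nitrogen. Within the data shown here, the only step that bears on this change is the exchange of one dimethylphenyl pattern for another, a number 3.2 percentage points lower from compound 1 to compound 2 (within the scatter), which was within the scatter. No other comparison is available. The expectation for compound 3 in this assay is therefore no step beyond the scatter, and that expected step is a number 1.2 percentage points higher from compound 2 to compound 3 (within the scatter). Compound 3 is estimated at 51%, with a range from 38% to 64%.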

Compound 3, a percentage reported as inhibition, at one concentration (the size of the read-out at that concentration, not a potency): 38.3%
The estimate for compound 3 lay 12.7 percentage points above the measured number; the range from low to high includes it.
By their numbers in this assay, from the lowest: compound 3; then compounds 2 and 1 (each within the scatter of the next).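

In this assay, within the data shown here, the exchange of one dimethylphenyl pattern for another had stayed within the scatter, whereas 4-ethylphenyl on the aromatic nitrogen gives the first steps beyond it (a number 11.5 percentage points lower from compound 2 to compound 3 (beyond the scatter); a number 14.7 percentage points lower from compound 1 to compound 3 (beyond the scatter)). The position therefore responds to the arrangement of the carbons on this phenyl ring, since 4-ethylphenyl and 3,5-dimethylphenyl have the same 8 heavy atoms (8 carbon) and differ only in how these are joined. Nothing available explains why this arrangement gives the lower number.

The compounds shown leave open whether the ethyl chain itself or the absence of two separate methyl groups accounts for the step. Nor do they show how this position would respond to a single methyl group, a longer chain such as propyl, or an amine on the phenyl ring.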